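Compound 1 and its methyl counterpart: cytotoxicity notes

The compounds below may be only part of what the source reports. "The series", "measured", "known", "first", "only" and "open" are said of these compounds alone.

In an ADME assay on WI-38 cells (Homo sapiens) for cytotoxicity, read by MTT assay, with a stated time of 48 h (a higher number here means a weaker inhibitor, a lower number a stronger inhibitor), compound 1 `O=C(NCCOC(=S)Nc1ccc(F)cc1)c1cccnc1` gives only a limit, > 800000 nM. Compound 2 `NC(=S)c1ccc(OC(=O)c2cccnc2)cc1` also gives only a limit, > 800000 nM. Compound 3 `O=C(Oc1ccc(-c2cc(=S)ss2)cc1)c1cccnc1` gives a number, 734000 nM. As far as these compounds go, compound 1 and compound 2 therefore share (the limit of > 800000 nM in this assay, at which 2 of the 3 values shown sit), so the exact position of compound 1 in this assay is unknown.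

Compound 4 `Cc1ccc(NC(=S)OCCNC(=O)c2cccnc2)cc1` differs from compound 1 by methyl in place of fluoro on an aromatic carbon. This is methyl in place of fluoro on an aromatic carbon of a six-membered aromatic ring of carbon only, para to a large group.

For the measured compounds named here, no measured step covers this exchange. Going by the values given here, the only step available, an at least 1.0-fold lower number from compound 2 to compound 3 (0.03 log units; that floor lies within the scatter), involves a much larger replacement on a different compound pair, and it bears on the present change only indirectly. Even so, that larger replacement shows no change beyond the scatter, and compound 3 at 734000 nM gives the only number in the series.

No step beyond the scatter is therefore expected, and a limit reading is the likeliest outcome. The estimated change is a number no higher from compound 1 to compound 4 (the limit leaves the size open), with no direction expected. The value expected for compound 4 is 800000 nM, with an estimated range from 450000 nM to 1400000 nM.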

Compound 4, half-maximal inhibitory concentration: > 800000 nM
Compound 4: a limit, no number; the forecaster's own chance of this, stated with the estimate: 70%; the middle value sits exactly at the limit.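

Compound 1 and compound 4 both give only a limit in this assay, so no step between them can be read: the limit of > 800000 nM in this assay, at which 3 of the 4 values shown sit.

The compounds shown leave open whether methyl in place of fluoro on an aromatic carbon changes this reading at all, and in which direction.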